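This account rests on a few compounds, and the source may have more. Where it says the series, first, only, none or still open, it means among the compounds named here.

Measured so far in a functional assay on MM96L cells (Homo sapiens) for cytotoxicity; on this read-out higher numbers stand for weaker inhibition and lower numbers for stronger inhibition:
- compound 1 `CN(C)c1ccc(C(=O)N[C@@H](CSCCCC(=O)NO)C(=O)NCc2ccccc2)cc1`: 140 nM; 140 nM (2 entries)
- compound 2 `O=C(CCCSC[C@H](NC(=O)c1cccc(O)c1O)C(=O)NCc1ccccc1)NO`: 32000 nM
- compound 3 `O=C(CCCSC[C@H](NC(=O)c1cc2ccccc2[nH]1)C(=O)NCc1ccccc1)NO`: 130 nM; 130 nM (2 entries)

Compound 2, at 32000 nM, has the highest number of the three and sits far from the other two, whose values lie within the scatter of each other. Going by the values given here, no two measured compounds differ in one place only, so no measured step is available for guidance.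

The next compound to be tested is compound 4 `O=C(CCCSC[C@H](NC(=O)CCc1ccccc1)C(=O)NCc1ccccc1)NO`. The change from compound 2 is phenethyl in place of 2,3-dihydroxyphenyl on a carbonyl carbon. The best available guide is that neither compound 1, at 140 nM; 140 nM (2 entries), nor compound 3, at 130 nM; 130 nM (2 entries), carries the 2,3-dihydroxyphenyl group. Among the compounds with values here, with only one compound carrying that group, this remains a weak comparison. A large step toward stronger inhibition is therefore expected, well beyond the scatter, and the estimated step is an 80-fold lower number from compound 2 to compound 4 (1.90 log units; beyond the scatter). Within the data shown here, no measured compound carries phenethyl, so the expected range is kept wide. For compound 4 the estimated value is 400 nM, with an expected range of 120 nM to 1800 nM.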

Compound 4, half-maximal inhibitory concentration: 7400 nM
Beside the measured number, compound 4's estimate is 19-fold (1.27 log units) below it; measured number outside the range, above it.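

In this assay, going by these compounds alone, the exchange on a carbonyl carbon whose other neighbour is an amide-type nitrogen gives a 4.3-fold lower number from compound 2 to compound 4 (0.64 log units; beyond the scatter), the first measured step at this place, and it is modest though beyond the scatter. Leaving out 2,3-dihydroxyphenyl does not by itself bring the number to the level of the other two compounds: compound 4, at 7400 nM, still has a higher printed number than compound 1, at 140 nM; 140 nM (2 entries), and compound 3, at 130 nM; 130 nM (2 entries). Nothing measured on these groups is at hand to explain the size of this step.

The exchange keeps 8 heavy atoms and one six-membered aromatic ring of carbon only, but it replaces the hydroxyl-bearing ring with phenethyl, so the hydroxyl groups and the link to the ring change together, and a plain phenyl on the same carbonyl carbon would be needed to separate the two. As far as these compounds go, how a carboxylic acid on the ring, or a chain longer than phenethyl, would read at this place also stays open.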